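This account rests on a few compounds, and the source may have more. Where it says the series, first, only, none or still open, it means among the compounds named here.

In a functional assay on HCT-116 cells (Homo sapiens) for inhibition, read by MTT assay, with a stated time of 2 days (a higher number here means a weaker inhibitor of growth, a lower number a stronger inhibitor of growth), compound 1 `Nc1ccccc1NC(=O)CCCNCC(=O)Nc1cccc(Cl)c1` gives 75000 nM and compound 2 `Nc1ccccc1NC(=O)CCCNCC(=O)Nc1cc(Cl)ccc1Cl` gives 78000 nM on the same read-out, so compound 2 stands within the scatter of compound 1. Within the data shown here, compound 3 `Nc1ccccc1NC(=O)CCCNCC(=O)Nc1ccccc1Cl` has no measurement yet. Among the measured compounds shown here, the one change from compound 2 to compound 3 is hydrogen in place of chloro on an aromatic carbon and amounts to hydrogen in place of chloro on an aromatic carbon, turning 2,5-dichlorophenyl into 2-chlorophenyl. For the measured compounds named here, the only measured step of this kind runs the other way, chloro in place of hydrogen on an aromatic carbon. Its size is a 1.0-fold higher number from compound 1 to compound 2 (0.02 log units; within the scatter) as measured, so no step beyond the scatter is expected in this assay for this change. The expected step is a 1.0-fold lower number from compound 2 to compound 3 (0.02 log units; within the scatter) on this single guide. For compound 3 the estimated value is 75000 nM with an expected range from 40000 nM to 130000 nM in a repeat measurement.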

Compound 3, concentration for total growth inhibition: > 100000 nM
Compound 3: only a limit was reported (the forecaster's own chance of this, stated with the estimate: 10%); at least 1.3-fold (0.12 log units) between middle value and limit.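

In this assay compound 3 reads > 100000 nM, which is a limit and not a number. Taking the chloro group off 2,5-dichlorophenyl gives an at least 1.2-fold higher number from compound 2 to compound 3 (0.10 log units; that floor lies within the scatter), and 2-chlorophenyl in place of 3-chlorophenyl gives an at least 1.3-fold higher number from compound 1 to compound 3 (0.12 log units; that floor lies within the scatter). Unlike a 1.0-fold higher number from compound 1 to compound 2 (0.02 log units; within the scatter), which has a measured size, these two steps have only a floor, so this position could matter little or much, and one thing sets that bound: the limit of > 100000 nM in this assay, at which 1 of the 3 values shown sits.

The compounds shown leave open how large the step from 2,5-dichlorophenyl to 2-chlorophenyl truly is. They also leave open how a fluoro or methoxy group would read in place of the chloro group on this ring, and what a longer chain in the shared core would do to these values.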